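A few compounds are considered here, and "the series" means these few. Any claim that something is new, unique, unknown or untested is made for them only; others in the source may bear on it.

The measured compounds in a functional assay on the whole organism (stomach) for inhibition, with Canis familiaris (Canis lupus familiaris) as the target, at a dose of 5 mg/kg by the intravenous route; on this read-out higher numbers stand for a stronger effect at the one dose given and lower numbers for a weaker effect:
compound 1, `Cc1nc2c(OCc3ccccc3)cccn2c1C#N`, gives 4%;
compound 2, `Cc1nc2c(OCc3ccccc3)cccn2c1CO`, gives 80%;
compound 3, `CSCc1c(C)nc2c(OCc3ccccc3)cccn12`, gives 8%.

Compound 2 stands highest of the three, separated from its nearest neighbour by a number 72 percentage points lower from compound 2 to compound 3 (beyond the scatter) and from the furthest by a number 76 percentage points higher from compound 1 to compound 2 (beyond the scatter). Both of those steps are large and lie beyond the scatter, so compound 2 is genuinely the strongest of the three on this read-out.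

Compound 4, `CCSCc1c(C)nc2c(OCc3ccccc3)cccn12`, differs from compound 2 in a single place: ethylsulfanyl in place of hydroxy on a saturated chain carbon bound to an aromatic carbon. Among the compounds with values here, the change is a close relative of the one that turns compound 2 into compound 3, where methylsulfanyl rather than ethylsulfanyl took the place of the hydroxy, and that step was a large fall, a number 72 percentage points lower from compound 2 to compound 3 (beyond the scatter). The cyano and methylsulfanyl compounds, moreover, sit together at the bottom, with a number 4 percentage points higher from compound 1 to compound 3 (within the scatter) within the scatter. A large downward step in this assay is therefore expected for compound 4, roughly matching the fall to compound 3. Compound 4 is estimated to give 8%, with a range from 0% to 25%. This estimate corresponds to an expected step of a number 72 percentage points lower from compound 2 to compound 4 (beyond the scatter).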

Compound 4, a percentage reported as inhibition, in the whole organism at one dose (the size of the read-out at that dose, not a potency): 0%
Compound 4: the middle estimate sits 8 percentage points above what was measured, within the range that was stated.
By their numbers in this assay, from the lowest: compounds 4, 1 and 3 (each within the scatter of the next); then compound 2.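

In this assay, ethylsulfanyl in place of hydroxy on this saturated chain carbon gives a number 80 percentage points lower from compound 2 to compound 4 (beyond the scatter), so the loss seen with methylsulfanyl also appears with a second sulfur group. Adding a methyl to the sulfur group gives a number 8 percentage points lower from compound 3 to compound 4 (within the scatter), so the two sulfur compounds cannot be told apart, and the comparison with the nitrile gives a number 4 percentage points lower from compound 1 to compound 4 (within the scatter), which places compound 4 within the scatter of compound 1 as well. Among these four compounds, only compound 2, with its hydroxymethyl group, keeps a large effect, and nothing measured here explains the difference.

From the compounds shown here alone, whether that effect needs the hydroxy itself remains open, as a methoxy or an amine on the same carbon would test this. A longer chain carrying a terminal hydroxy would show whether the oxygen can also sit further out.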